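This account rests on a few compounds, and the source may have more. Where it says the series, first, only, none or still open, it means among the compounds named here.

Measured compounds:
compound 1 `CC1(c2ccc(-c3ccc4ccccc4c3)[nH]c2=O)OC(=O)NC1=O` — 20 nM
compound 2 `CC1(c2ccc(-c3ccc4ccccc4c3)[nH]c2=O)NC(=O)NC1=O` — 316 nM
compound 3 `CC1(c2ccc(-c3ccc4ccccc4c3)[nH]c2=O)CNC(=O)N1` — 39.8 nM

In a functional assay on CHO cells for antagonist activity at prostaglandin E2 receptor EP3 subtype (Homo sapiens), read by FLIPR, with a stated time of 1 h (a lower number here means a stronger inhibitor, a higher number a weaker inhibitor), compound 3 gives 39.8 nM, the second highest of the three numbers; the nearest of the others lies within the scatter (a 2.0-fold higher number from compound 1 to compound 3 (0.30 log units; within the scatter)), the furthest does not (a 7.9-fold lower number from compound 2 to compound 3 (0.90 log units; beyond the scatter)). Compound 4 `CC1(c2ccc(-c3ccc4ccccc4c3)[nH]c2=O)CNC(=O)O1` is not yet measured; it differs from compound 3 by 5-methyl-2-oxo-1,3-oxazolidin-5-yl in place of 4-methyl-2-oxoimidazolidin-4-yl on an aromatic carbon. The measured step that bears on this exchange of a ring amide for a ring carbamate is a 16-fold higher number from compound 1 to compound 2 (1.20 log units; beyond the scatter), which runs the same exchange the other way on the dioxo ring, while a 2.0-fold higher number from compound 1 to compound 3 (0.30 log units; within the scatter) shows the single-oxo ring keeping pace with the dioxo carbamate. Together they point to a lower number for compound 4 in this assay, at most a modest step. Compound 4 is therefore estimated at 13 nM (range 4 nM to 40 nM), the expected step being a 3.1-fold lower number from compound 3 to compound 4 (0.49 log units; beyond the scatter).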

Compound 4, inhibition constant: 79.4 nM
Compound 4: the middle estimate sits 6.1-fold (0.79 log units) below what was measured; the whole stated range lies below it.
By their numbers in this assay, from the lowest: compounds 1, 3 and 4 (each within the scatter of the next, the first and the last beyond it); then compound 2.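

In this assay the swap to 5-methyl-2-oxo-1,3-oxazolidin-5-yl on the single-oxo ring gives no step beyond the scatter (a 2.0-fold higher number from compound 3 to compound 4 (0.30 log units; within the scatter)), so the large gap between the dioxo rings (a 16-fold higher number from compound 1 to compound 2 (1.20 log units; beyond the scatter)) does not carry over. Losing one ring carbonyl runs in opposite directions: (a 4.0-fold higher number from compound 1 to compound 4 (0.60 log units; beyond the scatter)) from the 5-methyl-2,4-dioxo-1,3-oxazolidin-5-yl group, but (a 7.9-fold lower number from compound 2 to compound 3 (0.90 log units; beyond the scatter)) and (a 4.0-fold lower number from compound 2 to compound 4 (0.60 log units; beyond the scatter)) from the 4-methyl-2,5-dioxoimidazolidin-4-yl group, which leaves compound 2 the weakest of the four. Nothing available accounts for this reversal. Still open, going by these compounds, is how an ethyl group in place of the methyl, or an amine or carboxylic acid on the ring, would read.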